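Adding a Methoxy to the Ketone-Bearing Ring of Compound 3

A few compounds are considered here, and "the series" means these few. Any claim that something is new, unique, unknown or untested is made for them only; others in the source may bear on it.

Compound 3 `COc1ccc(C(=O)/C=C/c2cc(-c3cc(OC)c(OC)c(OC)c3)n[nH]2)cc1OC` is measured in a functional assay on MDA-MB-435 cells (Homo sapiens) for inhibition, read by sulforhodamine B assay, with a stated time of 48 h (a lower number here means a stronger inhibitor of growth, a higher number a weaker inhibitor of growth), at 1340 nM. Of the three compounds measured, compound 3 gives the lowest number, but its neighbour compound 2 `COc1ccc(-c2cc(/C=C/C(=O)c3cc(OC)c(OC)c(OC)c3)[nH]n2)cc1OC`, with 1780 nM, lies within the scatter of it, so the two cannot be ordered. The furthest is compound 1 `COc1cc(-c2cc(/C=C/C(=O)c3ccc(Cl)c(Cl)c3)[nH]n2)cc(OC)c1OC`, which gives 5650 nM; the single step known, a 4.2-fold lower number from compound 1 to compound 3 (0.62 log units; beyond the scatter), concerns the exchange of one ketone-bearing aryl group for another and is the only one shown that goes beyond the scatter.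

Compound 4 `COc1cc(C(=O)/C=C/c2cc(-c3cc(OC)c(OC)c(OC)c3)n[nH]2)cc(OC)c1OC` differs from compound 3 in one place: methoxy in place of hydrogen on an aromatic carbon. Within the data shown here, no measured pair isolates this change, since the one step known alters a different group entirely. With nothing shown to point either way, the step is expected to be a 1.0-fold lower number from compound 3 to compound 4 (0.01 log units; within the scatter), that is, no change beyond the scatter. Compound 4 is therefore estimated at 1300 nM, within a range of 500 nM to 3500 nM.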

Compound 4, concentration for 50% growth inhibition: 1490 nM
Estimate against measurement, compound 4: 1.1-fold (0.06 log units) below; low and high end bracket the measured number.
By their numbers in this assay, from the lowest: compounds 3, 4 and 2 (each within the scatter of the next); then compound 1.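

In this assay, a methoxy in place of hydrogen on the ketone-bearing aryl group gives a 1.1-fold higher number from compound 3 to compound 4 (0.05 log units; within the scatter), and the same exchange on the other aryl group gives a 1.2-fold lower number from compound 2 to compound 4 (0.08 log units; within the scatter). Among these compounds, both steps lie within the scatter, so compound 4 cannot be told apart from either compound with one methoxy fewer, and the only step beyond the scatter remains the exchange of the ketone-bearing aryl group in a 4.2-fold lower number from compound 1 to compound 3 (0.62 log units; beyond the scatter). No supporting evidence on this result is available to explain it.

What the compounds shown leave open is whether a hydroxyl group, an amine or a longer chain such as ethoxy at this place would stay within the scatter as well. They also leave open what happens when a methoxy already present on either aryl group is removed.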